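A few compounds are considered here, and "the series" means these few. Any claim that something is new, unique, unknown or untested is made for them only; others in the source may bear on it.

Measured compounds:
- compound 1, `CC#C[C@@H](CC(=O)O)c1ccc(OC[C@H]2COc3ccc(Cl)cc3O2)cc1`: 86%
- compound 2, `CC#C[C@@H](CC(=O)O)c1ccc(OC[C@@H]2COc3ccc(Cl)cc3O2)cc1`: 65%

Compound 1 stands highest of the two numbers in a functional assay on HEK293 cells for agonist activity at Free fatty acid receptor 1 (Homo sapiens), read by fluorescence and calcium flux, with a stated time of 10 min; a higher number here means a larger maximal response, a lower number a smaller maximal response; its nearest neighbour is compound 2, and the change a number 21 percentage points lower from compound 1 to compound 2 (beyond the scatter) lies beyond the scatter. The size of that step rests on (the fact that compounds 1 and 2 differ only in the configuration as drawn), so it speaks only to the drawn configuration at a saturated ring carbon and says nothing about substitution of the aromatic rings.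

Compound 3, `CC#C[C@@H](CC(=O)O)c1ccc(OC[C@H]2COc3cc(Br)c(Cl)cc3O2)cc1`, is not yet measured. It differs from compound 1 by bromo in place of hydrogen on an aromatic carbon, on the ring that carries the chloro group. For the measured compounds named here, no measured step here concerns a change of that kind: the only step in hand, from compound 1 to compound 2, involves no change of atoms, and so it gives no guide to the effect of adding a bromo group. With the configuration kept as in compound 1, the expectation is therefore that the maximal response of compound 3 stays near that of compound 1, with a step of a number 2 percentage points lower from compound 1 to compound 3 (within the scatter) that is expected to lie within the scatter. For compound 3 the estimate is 84%, with a range from 64% to 104%.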

Compound 3, largest response reached (Emax), in percent of the reference or control that the assay uses: 82%
Compound 3: middle estimate off by 2 percentage points, on the high side; the measured number falls inside the stated range.
By their numbers in this assay, from the lowest: compound 2; then compounds 3 and 1 (each within the scatter of the next).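

In this assay, for the compounds shown here, the step of a number 4 percentage points lower from compound 1 to compound 3 (within the scatter) is the first in this set to involve a change of atoms rather than of drawn configuration. It shows that, with the configuration of compound 1 kept, the aromatic carbon ortho to a chloro group can carry bromo in place of hydrogen without a maximal response that can be told apart from that of compound 1, so this position accepts one added heavy atom in this assay. The information available gives no reason for this outcome, and the only point on record concerns the stereocentre, which has no bearing on the bromo group.

The compounds shown leave open whether a different group on this same aromatic carbon, such as fluoro, methyl, methoxy, a nitrile or an amine, would also leave the maximal response where it stands, or whether a larger chain would be accepted there. They also leave open whether bromo at this position would behave the same way with the ring stereocentre drawn as in compound 2, and how far the chloro group itself matters to the response.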